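Swapping the difluorophenyl for methoxy on the amide carbonyl

The source may report more compounds than this note shows. Statements on the series, on what has been measured and on what is new or still open speak of the compounds shown alone.

Measured in an assay on CHO-K1 cells for displacement of a labelled ligand from prostaglandin E2 receptor EP1 subtype (Homo sapiens); on this read-out lower numbers stand for stronger inhibition and higher numbers for weaker inhibition:
Compound 1, `Cc1cc(C(=O)Nc2ccccn2)nn1Cc1cc(Cl)ccc1OCc1ccccc1`: 126 nM
Compound 2, `Cc1cc(NC(=O)C(C)C)nn1Cc1cc(Cl)ccc1OCc1ccccc1`: 25.1 nM
Compound 3, `Cc1cc(NC(=O)c2c(F)cccc2F)nn1Cc1cc(Cl)ccc1OCc1ccccc1`: 12.6 nM

All three compounds share one core and differ only in the group attached to the pyrazole carbon. Compound 3 carries the lowest number of the three, but one of its two steps is a 2.0-fold lower number from compound 2 to compound 3 (0.30 log units; within the scatter) and so lies inside the usual scatter, while the other is a 10-fold lower number from compound 1 to compound 3 (1.00 log units; beyond the scatter) and is clearly real. Compound 2 itself stands a 5.0-fold lower number from compound 1 to compound 2 (0.70 log units; beyond the scatter).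

Compound 4, `COC(=O)Nc1cc(C)n(Cc2cc(Cl)ccc2OCc2ccccc2)n1`, is not yet measured. It is built from compound 3 by the change (methoxy in place of 2,6-difluorophenyl on a carbonyl carbon). For the measured compounds named here, the one measured step that touches the same carbonyl carbon is a 2.0-fold lower number from compound 2 to compound 3 (0.30 log units; within the scatter), which shows that exchanging isopropyl for 2,6-difluorophenyl there moved the number only within the scatter. Going by the values given here, a methoxy group is a further departure from both of those, and no measured step tells how far a group of two heavy atoms can go. The expectation for compound 4 in this assay is therefore a small loss at most, a 2.0-fold higher number from compound 3 to compound 4 (0.30 log units; within the scatter), most likely within the scatter. Compound 4 is estimated at 25 nM, with a range from 8 nM to 80 nM.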

Compound 4, half-maximal inhibitory concentration: 200 nM
Estimate against measurement, compound 4: 8.0-fold (0.90 log units) below, outside the stated range (above it).
By their numbers in this assay, from the lowest: compounds 3 and 2 (each within the scatter of the next); then compounds 1 and 4 (each within the scatter of the next).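

In this assay, for the compounds shown here, this carbonyl carbon proves much less forgiving than the earlier compounds suggested: isopropyl and 2,6-difluorophenyl could replace each other within the scatter, yet methoxy gives a 16-fold higher number from compound 3 to compound 4 (1.20 log units; beyond the scatter) and an 8.0-fold higher number from compound 2 to compound 4 (0.90 log units; beyond the scatter) and both of these steps lie beyond the scatter. What sits on this carbonyl carbon therefore does matter, and the tolerance seen for the first two groups does not extend to the methoxy group, which turns the ((2,6-difluorophenyl)carbonyl)amino group into (methoxycarbonyl)amino. The clear advantage that compound 2 and compound 3 held over compound 1 is also absent here, since the change of (pyridin-2-yl)carbamoyl to (methoxycarbonyl)amino gives only a 1.6-fold higher number from compound 1 to compound 4 (0.20 log units; within the scatter) and that step stays inside the scatter.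

The compounds shown leave open whether the loss goes with the oxygen attached to the carbonyl carbon or with the shorter group, and a plain methyl, an ethoxy or a tert-butoxy group on that carbon would help separate these two readings. Nothing measured here explains the size of the loss.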